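The source may report more compounds than this note shows. Statements on the series, on what has been measured and on what is new or still open speak of the compounds shown alone.

Three related compounds share one core, a benzamidine carrying a thiophene that in turn carries a further aromatic ring. Compound 1, `N=C(N)c1ccc(-c2ccc(-c3cc(Cl)cc(Cl)c3)s2)cc1`, was prepared, but in a functional assay on OVCAR-4 cells (Homo sapiens) for inhibition, read by sulforhodamine B assay, with a stated time of 48 h (on this read-out higher numbers stand for weaker inhibition of growth and lower numbers for stronger inhibition of growth), compound 1 has no number: its entry reads "not determined" (no result reported). Compound 2, `N=C(N)c1ccc(-c2ccc(-c3ccc(F)cc3)s2)cc1`, gives 1630 nM in this assay. Compound 3, `N=C(N)c1ccc(-c2ccc(-c3ccc(Cl)cc3)s2)cc1F`, gives 224 nM in this assay, the lowest of the two numbers available, and therefore the stronger inhibitor of growth of the two; the gap to compound 2 is wide enough to count as a real difference rather than noise.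

Compound 4, `N=C(N)c1ccc(-c2ccc(-c3ccccc3)s2)cc1F`, is the next compound to be tested. It differs from compound 3 in a single place: hydrogen in place of chloro on an aromatic carbon. Among the measured compounds shown here, no pair of measured compounds differs in exactly this way, so nothing measured here shows directly what this change does. The general picture in this set is that the halogen-bearing outer ring in compound 3 goes with the strongest growth inhibition seen so far, which suggests that removing that chloro will cost some activity. The expected step from compound 3 to compound 4 in this assay is therefore a 2.5-fold higher number from compound 3 to compound 4 (0.39 log units; beyond the scatter), a move toward weaker inhibition, modest but probably beyond the scatter. Compound 4 is accordingly expected to give about 550 nM in this assay, with a plausible range from 220 nM to 1500 nM.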

Compound 4, concentration for 50% growth inhibition: 10400 nM
Beside the measured number, compound 4's estimate is 19-fold (1.28 log units) below it; the whole stated range lies below it.
By their numbers in this assay, from the lowest: compound 3; then compound 2; then compound 4.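

Going from 4-chlorophenyl to phenyl in this assay brings a 46-fold higher number from compound 3 to compound 4 (1.67 log units; beyond the scatter) and is a large move toward weaker inhibition of growth. Among the compounds shown here, this is the first direct reading of this position, since no earlier pair of measured compounds differed in one place only. It shows that a single chlorine atom on an aromatic carbon, para to a large group, carries much of the growth inhibition seen with compound 3, and no measurement shown here accounts for the size of this loss.

The compounds shown leave open whether chlorine itself matters at this position or whether other groups, such as bromo, methyl, methoxy or an amine, would serve as well; compound 2 carries fluoro there but also lacks the fluoro on the core, so it cannot settle the question. They also leave open whether the chlorine would count for as much without the core fluoro that compound 3 and compound 4 share, and a direct test would need a pair differing only at the outer-ring position.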